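Carbamate Variant Tested Against a Lipophilicity Ceiling

A few compounds are considered here, and "the series" means these few. Any claim that something is new, unique, unknown or untested is made for them only; others in the source may bear on it.

Compound 1 `CNC(=O)c1cc(C)n(Cc2cc(Cl)ccc2OCc2ccccc2)n1` stands at the upper edge of what the numbers show. In a physicochemical assay for lipophilicity, at pH 7.4 (on this read-out higher numbers stand for higher lipophilicity and lower numbers for lower lipophilicity), compound 1 gives > 3.7, which is a limit of the assay rather than a number. Compound 2 `Cc1cc(C(=O)Nc2c(F)cccc2F)nn1Cc1cc(Cl)ccc1OCc1ccccc1` gives 3.7 in this assay. Compound 3 `Cc1cc(NC(=O)C2CCOC2)nn1Cc1cc(Cl)ccc1OCc1ccccc1` gives > 3.7 in this assay, again a limit. The measured steps are a number no higher from compound 1 to compound 2 (the limit leaves the size open), a step that the two limits leave unreadable from compound 1 to compound 3 and a number no lower from compound 2 to compound 3 (the limit leaves the size open), and none of them yields a readable size because of the limit of > 3.7 in this assay, at which 2 of the 3 values shown sit. Compound 4 `Cc1cc(NC(=O)OCc2ccccn2)nn1Cc1cc(Cl)ccc1OCc1ccccc1` differs from compound 1 in this way: (((pyridin-2-yl)methoxy)carbonyl)amino in place of methylcarbamoyl on an aromatic carbon. The closest measured step, a step that the two limits leave unreadable from compound 1 to compound 3, likewise swaps the methylcarbamoyl for an amino-linked group, yet its size stays unreadable, so no direction can be read from the data. Compound 4 is nonetheless expected to remain at the high end, with an estimated 4.3 (range 3.7 to 4.9). The step that the limit leaves unreadable from compound 1 to compound 4 is therefore an expectation, not a measurement.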

Compound 4, distribution coefficient: 3.1
For compound 4 the middle estimate is 1.20 log units above the measured one; the measured number lies below the stated range.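

In this assay, this position on the aromatic carbon now gives steps with a readable direction, all downward, once (((pyridin-2-yl)methoxy)carbonyl)amino is present: a number at least 0.60 log units lower from compound 1 to compound 4 (beyond the scatter), a number at least 0.60 log units lower from compound 3 to compound 4 (beyond the scatter) and a number 0.60 log units lower from compound 2 to compound 4 (beyond the scatter). The second of these isolates the change on the carbonyl carbon, with (pyridin-2-yl)methoxy in place of oxolan-3-yl. Only the last step has a fixed size, and the other two stay open-ended: the limit of > 3.7 in this assay, at which 2 of the 4 values shown sit.

The compounds shown leave open whether phenylmethoxy or dimethylamino on that carbonyl carbon would give a step of similar size.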